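Shortening the side chain: compound 2 to compound 3

The source may report more compounds than this note shows. Statements on the series, on what has been measured and on what is new or still open speak of the compounds shown alone.

Going by the values given here, compound 2 `NC(=O)CC[C@H](NC(=O)CN(c1nc(Cl)nc2[nH]cnc12)C1CC1)C(=O)O` gives 17.8% in a functional assay on the whole organism (Tail, strain ICR) with Mus musculus as the target, in the tail flick test, with a stated time of 120 min, at a dose of 25 umol/kg by the oral route (on this read-out higher numbers stand for a stronger effect at the one dose given and lower numbers for a weaker effect), and stands highest of the two numbers measured so far, though its nearest neighbour, compound 1 `NC(=O)C[C@H](NC(=O)CN(c1nc(Cl)nc2[nH]cnc12)C1CC1)C(=O)O`, with 17%, lies within the scatter of it. Among the compounds with values here, the only measured step, a number 0.8 percentage points higher from compound 1 to compound 2 (within the scatter), shows that carbamoylmethyl in place of carbamoyl changed the read-out by less than the scatter. Compound 3 `C[C@H](NC(=O)CN(c1nc(Cl)nc2[nH]cnc12)C1CC1)C(=O)O` is not yet measured; it differs from compound 2 as follows: hydrogen in place of carbamoylmethyl on a saturated chain carbon, two bonds along the chain from an amide-type nitrogen and a carbonyl carbon. Within the data shown here, no measured step removes this group altogether, so the lengthening step is only indirect guidance, and it points to a small step. A step of about a number 3.8 percentage points lower from compound 2 to compound 3 (within the scatter) is therefore expected, a slight weakening at most, not confidently beyond the scatter. For compound 3 the estimate in this assay is 14%, with a range from 4% to 28%.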

Compound 3, a percentage reported as activity, at one dose (the size of the read-out at that dose, not a potency): 28.4%
The estimate for compound 3 lay 14.4 percentage points below the measured number; the whole stated range lies below it.
By their numbers in this assay, from the lowest: compounds 1 and 2 (each within the scatter of the next); then compound 3.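

In this assay, the saturated chain carbon, two bonds along the chain from an amide-type nitrogen and a carbonyl carbon, now proves responsive: hydrogen in place of carbamoylmethyl gives a number 10.6 percentage points higher from compound 2 to compound 3 (beyond the scatter) and hydrogen in place of carbamoyl gives a number 11.4 percentage points higher from compound 1 to compound 3 (beyond the scatter) at the same place. The exchange of carbamoyl and carbamoylmethyl stayed within the scatter, whereas both changes to hydrogen lie beyond it, so among these three compounds the read-out separates loss of the carbamoyl-bearing group from its length. Nothing available accounts for the rise.

Open, on these data alone, is whether the read-out follows the carbamoyl group itself or any chain at this place, a question that a longer alkyl chain, an amine or a carboxylic acid there could address. Also open, as far as these compounds go, is whether this order holds at other doses.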